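The source may hold more compounds than are shown below. What is called first, only, known or untested is meant among the compounds shown, and "the series" means these compounds.

Of the compounds shown here, three of a shared core have been measured in a functional assay on SMMC-7721 cells (Homo sapiens) for antiproliferative activity, read by MTT assay, with a stated time of 72 h; a higher number here means a weaker inhibitor, a lower number a stronger inhibitor. Compound 1, `CN(C(=O)c1ccccc1)c1ccc2[nH]c(-c3n[nH]c4ccccc34)cc2n1`, gives 12500 nM in this assay. Within the data shown here, compound 2, `CN(C(=O)c1ccc(F)cc1)c1ccc2[nH]c(-c3n[nH]c4ccccc34)cc2n1`, gives 9150 nM in this assay, and the change a 1.4-fold lower number from compound 1 to compound 2 (0.14 log units; within the scatter) is the only one-point step among the measured compounds. Compound 3, `COc1ccc(S(=O)(=O)N(C)c2ccc3[nH]c(-c4n[nH]c5ccccc45)cc3n2)cc1`, gives 13000 nM in this assay; its number sits with those of compound 1 and compound 2, and the gaps to each of them fall within the scatter, so the three compounds are not separated by these data.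

Compound 4, `CN(c1ccc2[nH]c(-c3n[nH]c4ccccc34)cc2n1)S(=O)(=O)c1ccc(OC(F)(F)F)cc1`, differs from compound 3 by trifluoromethyl in place of methyl on an oxygen on an aromatic ring. Among the measured compounds shown here, no measured step touches this part of the molecule. For the measured compounds named here, the only step available, the one from compound 1 to compound 2, exchanges a hydrogen for a fluorine on an aromatic carbon and stays within the scatter, and it bears on compound 4 only loosely as another introduction of fluorine at the periphery. Nothing in the measured compounds therefore points to a shift beyond the scatter in this assay, in either direction.

For compound 4 the expected step is a 1.1-fold lower number from compound 3 to compound 4 (0.03 log units; within the scatter). Compound 4 is accordingly estimated at 12000 nM in this assay, with a likely range from 5000 nM to 30000 nM.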

Compound 4, half-maximal inhibitory concentration: 7160 nM
Compound 4: middle estimate off by 1.7-fold (0.22 log units), on the high side; measured number inside the range.
By their numbers in this assay, from the lowest: compounds 4, 2, 1 and 3 (each within the scatter of the next).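

In this assay, the exchange of methoxy for trifluoromethoxy gives a 1.8-fold lower number from compound 3 to compound 4 (0.26 log units; within the scatter), and this is the only reading of a change at this place, on an oxygen on an aromatic ring, among the compounds shown. Among these compounds, it adds to the earlier compounds a first sign that this oxygen can carry trifluoromethyl, with more heavy atoms than the methyl it replaces, without compound 4 being separated from compound 3 in this assay. No evidence on any property of these two groups is available to account for the step.

On these data alone, it remains open whether an amine or a carboxylic acid in place of the methoxy group, or a longer chain on the same oxygen, would give a step beyond the scatter. Among the compounds shown here, it is also open whether the same exchange would read alike on the carbonyl-linked compounds 1 and 2, since the one step here comes from the sulfonyl-linked pair alone, and whether it would hold in any cell line other than the one in this assay.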